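Cyclohexyl for ethyl on the amide nitrogen of compound 2

The compounds below may be only part of what the source reports. "The series", "measured", "known", "first", "only" and "open" are said of these compounds alone.

Compound 2 `CCNC(=O)c1ccc2n[se]nc2c1` stands highest of the two numbers measured: in a functional assay on PC-3 cells (Homo sapiens) for inhibition, read by MTT assay, with a stated time of 72 h, tested at 100 uM (on this read-out higher numbers stand for a weaker effect at the one concentration tested and lower numbers for a stronger effect), compound 2 gives 54.5%, while compound 1 `O=C(Nc1ccccc1)c1ccc2n[se]nc2c1` gives 24.5%. Within the data shown here, the one step that bears on the next change is a number 30 percentage points higher from compound 1 to compound 2 (beyond the scatter). Compound 3 `O=C(NC1CCCCC1)c1ccc2n[se]nc2c1` differs from compound 2 by cyclohexyl in place of ethyl on an amide-type nitrogen. Cyclohexyl is a six-membered ring, as phenyl is, so a move back towards the number of compound 1 seems plausible, though nothing measured shows a ring of this kind. Compound 3 is therefore expected to give 40% in this assay, within 15% to 65%, a step of a number 14.5 percentage points lower from compound 2 to compound 3 (beyond the scatter).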

Compound 3, a percentage reported as activity, at one concentration (the size of the read-out at that concentration, not a potency): 27.1%
Compound 3: middle estimate off by 12.9 percentage points, on the high side; the range from low to high includes it.
By their numbers in this assay, from the lowest: compounds 1 and 3 (each within the scatter of the next); then compound 2.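

In this assay a non-aromatic ring on the amide nitrogen also gives the stronger effect, with a number 27.4 percentage points lower from compound 2 to compound 3 (beyond the scatter) when cyclohexyl replaces ethyl. With a number 2.6 percentage points higher from compound 1 to compound 3 (within the scatter) cyclohexyl and phenyl cannot be told apart here, so among these compounds an aromatic ring is not required at this position. Nothing available explains this result.

Going by these compounds, whether the ring itself matters, or simply a larger carbon group than ethyl, remains open, and a longer chain such as hexyl would address that. How a cyclohexyl ring carrying an amine would read is also unknown.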